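The source may hold more compounds than are shown below. What is called first, only, known or untested is meant among the compounds shown, and "the series" means these compounds.

Of the compounds shown here, three sharing one core have been tested in a functional assay on HUVEC cells (Homo sapiens) for antiproliferative activity, read by MTT assay, with a stated time of 48 h; on this read-out higher numbers stand for weaker inhibition and lower numbers for stronger inhibition. Compound 1 `O=C(Nc1ccccc1)Nc1nnc(Sc2ncnc3scc(-c4ccncc4)c23)s1` gives 19300 nM, compound 2 `O=C(Nc1cccc(Cl)c1)Nc1nnc(Sc2ncnc3scc(-c4ccncc4)c23)s1` gives 21000 nM, and compound 3 `O=C(Nc1cccc(C(F)(F)F)c1)Nc1nnc(Sc2ncnc3scc(-c4ccncc4)c23)s1` gives 22400 nM. Compound 3 thus stands at the highest of the three numbers, although each of them lies within the scatter of the other two. Compound 4 `Cc1ccc(NC(=O)Nc2nnc(Sc3ncnc4scc(-c5ccncc5)c34)s2)cc1` has not yet been measured. It differs from compound 3 by 4-methylphenyl in place of 3-(trifluoromethyl)phenyl on an amide-type nitrogen. Going by the values given here, the steps that bear on this change each swap a group on an aromatic carbon: a 1.2-fold higher number from compound 1 to compound 3 (0.06 log units; within the scatter), a 1.1-fold higher number from compound 2 to compound 3 (0.03 log units; within the scatter) and a 1.1-fold higher number from compound 1 to compound 2 (0.04 log units; within the scatter). None of these moved beyond the scatter. The expected step for compound 4 is likewise none beyond the scatter, namely a 1.1-fold lower number from compound 3 to compound 4 (0.05 log units; within the scatter). Compound 4 is therefore estimated at 20000 nM, within a range from 9000 nM to 45000 nM.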

Compound 4, half-maximal inhibitory concentration: 19300 nM
Beside the measured number, compound 4's estimate is 1.0-fold (0.02 log units) above it, within the range that was stated.
By their numbers in this assay, from the lowest: compounds 1, 4, 2 and 3 (each within the scatter of the next).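

In this assay, 4-methylphenyl on the amide-type nitrogen gives a 1.2-fold lower number from compound 3 to compound 4 (0.06 log units; within the scatter), a 1.1-fold lower number from compound 2 to compound 4 (0.04 log units; within the scatter) and no change at the digits printed from compound 1 to compound 4 (within the scatter). The flat picture seen with phenyl, 3-chlorophenyl and 3-(trifluoromethyl)phenyl therefore also holds for a methyl group, and for a group named at the 4 rather than the 3 position of the ring. No measurement shown here accounts for this flatness.

On these data alone, whether an amine or a carboxylic acid on this ring would move the number beyond the scatter remains open. So does the outcome of replacing the ring with a longer chain.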